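This account rests on a few compounds, and the source may have more. Where it says the series, first, only, none or still open, it means among the compounds named here.

The measured compounds:
Compound 1, `Cc1ncnc2c1c(I)cn2[C@@H]1O[C@H](CO)[C@@H](O)[C@H]1O`, in a functional assay on CCRF-CEM cells (Homo sapiens), read by MTT assay, with a stated time of 72 h (on this read-out higher numbers stand for weaker inhibition and lower numbers for stronger inhibition), gives 5480 nM.
Compound 2, `C#Cc1cn([C@@H]2O[C@H](CO)[C@@H](O)[C@H]2O)c2ncnc(C)c12`, in this assay gives 5600 nM.
Compound 3, `C#Cc1cn([C@@H]2O[C@H](CO)[C@@H](O)[C@H]2O)c2nc(C)nc(N)c12`, in this assay gives only a limit of the assay, > 20000 nM.

Compound 4, `Cc1nc(N)c2c(I)cn([C@@H]3O[C@H](CO)[C@@H](O)[C@H]3O)c2n1`, has not yet been measured in this assay. It differs from compound 3 by iodo in place of ethynyl on an aromatic carbon. The same change, (iodo in place of ethynyl on an aromatic carbon), links compound 2 to compound 1, where it gave a 1.0-fold lower number from compound 2 to compound 1 (0.01 log units; within the scatter). The difference between the core of compound 2 and the core of compound 3 is not broken down here. The expectation for compound 4 rests on compound 3 sitting at the limit of > 20000 nM in this assay, at which 1 of the 3 values shown sits, and on the step of a 1.0-fold lower number from compound 2 to compound 1 (0.01 log units; within the scatter) lying within the scatter. Compound 4 is therefore expected near 30000 nM, between 15000 nM and 60000 nM. The estimated step is a step that the limit leaves unreadable from compound 3 to compound 4, most likely reported again only as a limit.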

Compound 4, half-maximal inhibitory concentration: 9030 nM
Beside the measured number, compound 4's estimate is 3.3-fold (0.52 log units) above it; measured number outside the range, below it.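

In this assay compound 3 is reported only as a limit of the assay, > 20000 nM. Replacing ethynyl with iodo on this core gives an at least 2.2-fold lower number from compound 3 to compound 4 (0.34 log units; beyond the scatter), while on the other core the same change gives a 1.0-fold lower number from compound 2 to compound 1 (0.01 log units; within the scatter). The two results therefore show that the change can give a step beyond the scatter on one core and none on the other, but they do not show that the step truly depends on the core: the same change on two cores in this assay, a 1.0-fold lower number (0.01 log units; within the scatter) from compound 2 to compound 1 and an at least 2.2-fold lower number (0.34 log units; beyond the scatter) from compound 3 to compound 4; the limit leaves it open whether they differ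

On these data alone, the true size of the step on the core of compound 3 remains open. So does how other groups on this aromatic carbon, such as bromo or nitrile, would behave on either core.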